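Two Aryl Piperidine Ethers Compared for Kinase Activation

The source may report more compounds than this note shows. Statements on the series, on what has been measured and on what is new or still open speak of the compounds shown alone.

Compound 1 `COC(=O)Nn1c(C[C@H]2CCC[C@H](OCc3cc(C(F)(F)F)cc(C(F)(F)F)c3)[C@@H]2c2ccccc2)n[nH]c1=O` and compound 2 `Cn1ccnc1CN1CCC[C@H](OCc2cc(Cl)cc(Cl)c2)[C@@H]1c1ccccc1` were both examined in an assay on isolated protein for activation of cGMP-dependent protein kinase 1 (Homo sapiens), read by ADP-Glo, with stated times of 120 min and 40 min; on this read-out higher numbers stand for an effect only at larger amounts of compound and lower numbers for an effect already at smaller amounts. Compound 1 gives 4500 nM in this assay, while compound 2 gives 165000 nM. Compound 2 therefore stands with the highest number of the two, and the gap from compound 1 to compound 2 lies beyond the scatter of repeated measurements.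

The next compound in the series is compound 3 `COc1ccc(C(=O)O)cc1CN1CCC[C@H](OCc2cc(Cl)cc(Cl)c2)[C@@H]1c1ccccc1`, which has not yet been measured in this assay. It differs from compound 2 in one place: 5-carboxy-2-methoxyphenyl in place of 1-methyl-1H-imidazol-2-yl on a saturated chain carbon bound to an amine nitrogen in a ring. For the measured compounds named here, no step between two measured compounds shows what such a change does here, so any expectation rests on compound 2 alone. Given the number of compound 2 in this assay 165000 nM, compound 3 is expected to move toward lower numbers, with a step estimated at a 2.8-fold lower number from compound 2 to compound 3 (0.44 log units; beyond the scatter). Compound 3 is estimated to give 60000 nM in this assay, within a range from 15000 nM to 250000 nM.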

Compound 3, half-maximal effective concentration: 123000 nM
For compound 3 the middle estimate is 2.1-fold (0.31 log units) below the measured one, and the stated range covers the measured number.
By their numbers in this assay, from the lowest: compound 1; then compounds 3 and 2 (each within the scatter of the next).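

At this position, on a saturated chain carbon bound to an amine nitrogen in a ring, this assay now has its first one-place comparison: 5-carboxy-2-methoxyphenyl in place of 1-methyl-1H-imidazol-2-yl gives a 1.3-fold lower number from compound 2 to compound 3 (0.13 log units; within the scatter) and leaves the read-out unchanged within the scatter. Two different groups, one a five-membered aromatic ring with 2 hetero atoms and no hydrogen-bond donor, the other a six-membered aromatic ring of carbon only with 1 hydrogen-bond donor, therefore read alike here. No measured information accounts for this result.

The compounds shown leave open whether an unsubstituted phenyl, or an amine in place of the carboxylic acid, would read any differently at this position. They also leave open whether a longer chain between this ring and the amine nitrogen would alter the read-out.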